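Amide series: next step in liver microsome clearance

The source may hold more compounds than are shown below. What is called first, only, known or untested is meant among the compounds shown, and "the series" means these compounds.

Three compounds of the shared core have been run in an ADME assay (liver) for metabolic stability, with Liver microsome (Homo sapiens) as the target, read by LC-MS, using microsomes, with a stated time of 60 min, tested at 1 uM; a lower number here means slower removal, a higher number faster removal of the compound. Compound 1 `Cc1cc(Br)ccc1C(=O)Nc1ccccn1` gives 97 uL/min. Compound 2 `Cc1c(C(=O)Nc2ccccn2)ccc(F)c1F` gives 154 uL/min. Compound 3 `Cc1ccccc1C(=O)Nc1cc(C#N)ccn1` gives 82 uL/min, the lowest of the three numbers; its gap to compound 1 and its gap to compound 2 both lie within the scatter, so no order among the three can be read from these values, and none of them counts as the slowest or fastest removed.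

The next compound, compound 4 `Cc1ccccc1C(=O)Nc1cc(C#Cc2ccccc2)ccn1`, differs from compound 3 in one place: 2-phenylethynyl in place of cyano on an aromatic carbon. The change sits on an aromatic carbon of a six-membered aromatic ring with one nitrogen, meta to a large group and opposite the ring nitrogen. Within the data shown here, no pair of measured compounds differs in one place, so the measured set says nothing directly about a change of this kind, and the outlook rests on the structural change alone. The estimate is for an upward step beyond the scatter, toward faster removal: a 2.4-fold higher number from compound 3 to compound 4 (0.39 log units; beyond the scatter). For compound 4 the estimated value in this assay is 200 uL/min, with a range from 100 uL/min to 400 uL/min.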

Compound 4, intrinsic clearance in a liver preparation (reported as CLH), per the amount of preparation that the assay uses in the Liver microsome assay: 27 uL/min
For compound 4 the middle estimate is 7.4-fold (0.87 log units) above the measured one; measured number outside the range, below it.
By their numbers in the Liver microsome assay, from the lowest: compound 4; then compounds 3, 1 and 2 (each within the scatter of the next).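

Among these compounds, at this position, on an aromatic carbon opposite the ring nitrogen, 2-phenylethynyl in place of cyano gives a 3.0-fold lower number from compound 3 to compound 4 (0.48 log units; beyond the scatter) in the Liver microsome assay, and this is the first step that can be read from one change. The position therefore takes a much larger group, one that enters with a six-membered aromatic ring of carbon only, and removal is slower rather than faster. The gain has a price in a second read-out, since in a physicochemical assay for solubility, read by nephelometry, measured as kinetic solubility, at pH 2, tested at 10 mg/mL (a higher number here means a more soluble compound, a lower number a less soluble compound), compound 3 gives 50 ug/mL and compound 4 gives 1.6 ug/mL, so the same change leaves the compound far less soluble: the measured solubility of compound 3, 50 ug/mL, and of compound 4, 1.6 ug/mL, a 31-fold lower number (1.49 log units; beyond the scatter)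

Both groups hold one triple bond outside aromatic rings, so this single step cannot show whether the slower removal belongs to the added carbon ring or to the size of the group as a whole, and it cannot show whether the lower solubility plays a part in it. Still open, going by these compounds, is whether an amine carried on the end of the 2-phenylethynyl group would hold the number in the Liver microsome assay low while raising the number in the physicochemical assay.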